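The compounds below may be only part of what the source reports. "The series", "measured", "known", "first", "only" and "open" are said of these compounds alone.

- Compound 1 `CN(C)c1nc(N)nc2c1ncn2/C=C1/CC1(CO)CO`: > 300000 nM
- Compound 2 `Nc1nc(SC2CCCC2)c2ncn(/C=C3/CC3(CO)CO)c2n1`: > 300000 nM

Both compounds were tested in an ADME assay on HFF cells (Homo sapiens) for cytotoxicity, with a stated time of 8 days (a lower number here means that less compound is tolerated, a higher number that more compound is tolerated), and neither gave a number. Compound 1 gives > 300000 nM, which is a limit of the assay. Compound 2 gives > 300000 nM, which is also a limit and not a number. Compound 2 therefore stands at the limit of > 300000 nM in this assay, at which 2 of the 2 values shown sit.

The next compound, compound 3 `CCCCNc1nc(N)nc2c1ncn2/C=C1/CC1(CO)CO`, has butylamino in place of cyclopentylsulfanyl on an aromatic carbon.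

For the measured compounds named here, only one measured step bears on this change, namely a step that the two limits leave unreadable from compound 1 to compound 2. It concerns the same cyclopentylsulfanyl group that now leaves, but it has no readable size. The data therefore offer no measured effect of this exchange. The expectation rests on the shared core, which in compound 2 reaches only the limit > 300000 nM. No step beyond the scatter is expected in this assay, although a lower number remains possible.

Compound 3 is estimated at 300000 nM, with an expected range from 100000 nM to 300000 nM. The expected change is a number no higher from compound 2 to compound 3 (the limit leaves the size open).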

Compound 3, half-maximal cytotoxic concentration: > 300000 nM
Compound 3 ended at the assay's limit; the forecaster's own chance of this, stated with the estimate: 75%; the middle value sits exactly at the limit.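

In this assay, for the compounds shown here, compound 3 gives > 300000 nM, which is a limit and not a number, so no step between compound 1, compound 2 and compound 3 can be read. The three compounds share one reading: the limit of > 300000 nM in this assay, at which 3 of the 3 values shown sit.

What they leave open is whether dimethylamino, cyclopentylsulfanyl and butylamino differ at all in how much compound the cells tolerate.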